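The source may hold more compounds than are shown below. What is called first, only, known or untested is meant among the compounds shown, and "the series" means these compounds.

Compound 1 `CCCc1ccc(NC(=O)C2CCN(C/C=C/c3ccccc3)CC2)cc1` is measured in a functional assay on A549 cells (Homo sapiens) for inhibition, read by MTT assay, with a stated time of 72 h (a higher number here means a weaker inhibitor, a lower number a stronger inhibitor), where it gives 9470 nM. Among the three compounds measured, compound 1 has the lowest number. Compound 2 `O=C(Nc1cccc(Cl)c1)C1CCN(C/C=C/c2ccccc2)CC1` gives 19100 nM, and compound 3 `O=C(Nc1ccccn1)C1CCN(C/C=C/c2ccccc2)CC1` gives 89300 nM. The step of a 2.0-fold higher number from compound 1 to compound 2 (0.30 log units; within the scatter) stays within the scatter, while the step of a 9.4-fold higher number from compound 1 to compound 3 (0.97 log units; beyond the scatter) is a modest loss, and the step of a 4.7-fold higher number from compound 2 to compound 3 (0.67 log units; beyond the scatter) points the same way.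

Compound 4 `O=C(NCc1ccccc1)C1CCN(C/C=C/c2ccccc2)CC1` has not yet been measured. It differs from compound 1 in one place: benzyl in place of 4-propylphenyl on an amide-type nitrogen. Among the measured compounds shown here, all three measured compounds carry a six-membered aromatic ring directly on the amide-type nitrogen, so no measured step shows what a benzyl there does; the only guidance is that changing this group has so far either done nothing beyond the scatter or weakened inhibition modestly. A small loss is therefore expected, with the step estimated as a 2.1-fold higher number from compound 1 to compound 4 (0.32 log units; beyond the scatter). Compound 4 is estimated at 20000 nM, in the expected range from 6000 nM to 70000 nM.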

Compound 4, half-maximal inhibitory concentration: > 100000 nM
Compound 4: no number, only a limit; the forecaster's own chance of this, stated with the estimate: 10%; middle value at least 5.0-fold (0.69 log units) from the limit.
By their numbers in this assay, from the lowest: compounds 1 and 2 (each within the scatter of the next); then compound 3. At a limit, above all of these: compound 4.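

In this assay, compound 4 gives no number, only a limit: the limit of > 100000 nM in this assay, at which 1 of the 4 values shown sits.

The three earlier compounds all carry a six-membered aromatic ring directly on the amide-type nitrogen, whereas benzyl does not, and this change gives an at least 10-fold higher number from compound 1 to compound 4 (1.02 log units; beyond the scatter), a large loss of inhibition, along with an at least 5.2-fold higher number from compound 2 to compound 4 (0.71 log units; beyond the scatter). Compound 4 cannot be clearly separated from the pyridin-2-yl compound, since an at least 1.1-fold higher number from compound 3 to compound 4 (0.04 log units; that floor lies within the scatter) has a floor that lies within the scatter.

Replacing 4-propylphenyl with benzyl both removes the propyl chain and moves the ring off the nitrogen, so the two effects cannot be told apart here. A plain phenyl or a 4-propylbenzyl group on this nitrogen would be needed to separate them.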